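Straightening a Branched Amide Chain on the Shared Core

The compounds below may be only part of what the source reports. "The series", "measured", "known", "first", "only" and "open" are said of these compounds alone.

Compound 3 `CC[C@@H]1C(=O)N(C)c2cnc(-n3ccc4cc(C(=O)NCC(C)C)ccc43)nc2N1C1CCCC1` gives 638 nM in a functional assay on K562 cells (Homo sapiens) for antiproliferative activity, read by CCK-8 assay, with a stated time of 72 h (a higher number here means a weaker inhibitor of growth, a lower number a stronger inhibitor of growth), and stands lowest of the three measured numbers. Its nearest neighbour is compound 2 `CC[C@@H]1C(=O)N(C)c2cnc(-n3ccc4cc(C(=O)NC(C)C)ccc43)nc2N1C1CCCC1` with 786 nM; the gap a 1.2-fold lower number from compound 2 to compound 3 (0.09 log units; within the scatter) is within the scatter. Furthest away is compound 1 `CC[C@@H]1C(=O)N(C)c2cnc(-n3ccc4cc(F)ccc43)nc2N1C1CCCC1` with 21200 nM, and the steps of a 27-fold lower number from compound 1 to compound 2 (1.43 log units; beyond the scatter) and a 33-fold lower number from compound 1 to compound 3 (1.52 log units; beyond the scatter) show that exchanging fluoro for an amide of either kind changes the number greatly.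

Compound 4 `CCCCNC(=O)c1ccc2c(ccn2-c2ncc3c(n2)N(C2CCCC2)[C@H](CC)C(=O)N3C)c1` differs from compound 3 only in the amide chain: propyl in place of isopropyl on a saturated chain carbon bound to an amide-type nitrogen. Among the compounds with values here, the step that bears most on this is the one between compound 2 and compound 3, which stayed within the scatter, so a branching change of similar size is expected to leave the number about where it is, with a step of a 1.0-fold higher number from compound 3 to compound 4 (0.01 log units; within the scatter). Compound 4 is therefore estimated at 650 nM, with a range from 300 nM to 1400 nM.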

Compound 4, concentration for 50% growth inhibition: 673 nM
Estimate against measurement, compound 4: 1.0-fold (0.02 log units) below; the measured number falls inside the stated range.
By their numbers in this assay, from the lowest: compounds 3, 4 and 2 (each within the scatter of the next); then compound 1.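

In this assay, butyl and isobutyl on the amide-type nitrogen cannot be told apart, with a 1.1-fold higher number from compound 3 to compound 4 (0.02 log units; within the scatter), and neither can butyl and isopropyl, with a 1.2-fold lower number from compound 2 to compound 4 (0.07 log units; within the scatter). Across these three amide chains, the branching tried so far leaves the number within the scatter, while butylcarbamoyl in place of fluoro still gives a 32-fold lower number from compound 1 to compound 4 (1.50 log units; beyond the scatter). Nothing measured here offers a reason for this. Still open, going by these compounds, is whether a much longer chain, such as octyl, or a chain ending in an amine would stay in this range. Also open, on these data alone, is whether a carboxylic acid in place of the amide would keep the large step from fluoro.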